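A few compounds are considered here, and "the series" means these few. Any claim that something is new, unique, unknown or untested is made for them only; others in the source may bear on it.

Measured so far:
Compound 1 `O=C(C1CCC2(CCC2)CC1)N1CC(c2nc(-c3cccc(Cl)c3)no2)C1`: in an assay on HEK293 cells for negative allosteric modulation of metabotropic glutamate receptor 5 (Homo sapiens), read by FLIPR (on this read-out lower numbers stand for stronger inhibition and higher numbers for weaker inhibition), compound 1 gives > 10000 nM, which is a limit of the assay rather than a number.
Compound 2 `O=C(c1ccc(F)cc1)N1CC(c2nc(-c3cccc(Cl)c3)no2)C1`: in this assay compound 2 gives 4000 nM.

Compound 2 therefore holds the only actual number shown; the other value is a limit (the limit of > 10000 nM in this assay, at which 1 of the 2 values shown sits). Compound 3 `O=C(N1CCCCC1)N1CC(c2nc(-c3cccc(Cl)c3)no2)C1` differs from compound 2 by piperidin-1-yl in place of 4-fluorophenyl on a carbonyl carbon. Among the compounds with values here, one measured step bears on this: an at least 2.5-fold lower number from compound 1 to compound 2 (0.39 log units; beyond the scatter), where a six-membered aromatic ring replaced non-aromatic rings on the same carbonyl carbon. The change to compound 3 runs the other way, from an aromatic ring to a non-aromatic one, so a step toward a higher number is expected, about a 2.3-fold higher number from compound 2 to compound 3 (0.35 log units; beyond the scatter). Compound 3 is expected to give roughly 9000 nM, within 3500 nM to 25000 nM, quite possibly reported only as a limit.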

Compound 3, half-maximal inhibitory concentration: > 10000 nM
Compound 3 was reported as a limit; the forecaster's own chance of this, stated with the estimate: 50%; middle value at least 1.1-fold (0.04 log units) away from the limit.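

Piperidin-1-yl in place of 4-fluorophenyl on the carbonyl carbon gives an at least 2.5-fold higher number from compound 2 to compound 3 (0.39 log units; beyond the scatter), so a second non-aromatic ring at this position also leaves activity out of numerical reach. Among the compounds shown, only the 4-fluorophenyl group gives an actual number, and the step between compound 1 and compound 3 cannot be read. Two of the three results are now limits: the limit of > 10000 nM in this assay, at which 2 of the 3 values shown sit.

On these data alone, it remains open whether the aromatic ring or its fluorine matters more. A plain phenyl or a pyridine ring on the same carbonyl carbon would help separate the two.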